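A few compounds are considered here, and "the series" means these few. Any claim that something is new, unique, unknown or untested is made for them only; others in the source may bear on it.

Of the compounds shown here, three sharing one core have been read in an ADME assay for pharmacokinetics, read by LC-MS, in phosphate buffer, with a stated time of 120 min, at pH 7.4, tested at 1 uM, in the presence of a further agent that is not named here; on this read-out higher numbers stand for a longer-lived compound and lower numbers for a shorter-lived compound. Among the measured compounds shown here, compound 2 (`O=C(/C=C/C(F)(F)F)Nc1ccccc1`), which carries a trifluoromethyl group, gives 0.267 h, the only true number in the set. Compound 1 (`C=C(C)C(=O)Nc1ccccc1`) reads > 8.53 h, which is a limit of the assay and not a number. Compound 3 (`C=C(F)C(=O)Nc1ccccc1`) reads > 8.53 h, which is again a limit. For the measured compounds named here, the one measured step, a step that the two limits leave unreadable from compound 1 to compound 3, has no readable size and concerns a different exchange, so it gives no size for the change considered here.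

Compound 4 (`CN(C)C/C=C/C(=O)Nc1ccccc1`) differs from compound 2 as follows: (dimethylamino)methyl in place of trifluoromethyl on a double-bonded chain carbon bound to a double-bonded chain carbon. Going by the values given here, no measured step covers this exchange, and the only other guide is the limit of > 8.53 h in this assay, at which 2 of the 3 values shown sit. Among the compounds with values here, with compound 2 at 0.267 h as the only compound with a true number, a longer half-life is expected for the new compound, though this is a weak basis. The expected change is a 15-fold higher number from compound 2 to compound 4 (1.18 log units; beyond the scatter), beyond the usual scatter. Compound 4 is estimated at 4 h, with an expected range of 1.2 h to 8.5 h.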

Compound 4, half-life: 1.93 h
Compound 4: the middle estimate sits 2.1-fold (0.32 log units) above what was measured, within the range that was stated.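

In this assay, (dimethylamino)methyl in place of trifluoromethyl on a double-bonded chain carbon bound to a double-bonded chain carbon gives a 7.2-fold higher number from compound 2 to compound 4 (0.86 log units; beyond the scatter). Among the compounds shown here, this is the first step in the set whose size can be read, and it shows that the half-life responds to the group carried at this place. Both ends of this step are true numbers, whereas the remaining values are limits and not numbers: the limit of > 8.53 h in this assay, at which 2 of the 4 values shown sit.

The compounds shown leave open whether the longer half-life goes with the amine itself or only with the loss of trifluoromethyl, and a plain methyl or a morpholine at this place would separate the two. They also leave open whether a longer chain carrying the same amine would move the half-life further.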